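The source may report more compounds than this note shows. Statements on the series, on what has been measured and on what is new or still open speak of the compounds shown alone.

Measured compounds in a functional assay on HepG2 cells (Homo sapiens) for antiproliferative activity, with a stated time of 72 h; a lower number here means that less compound is needed, a higher number that more compound is needed for the effect:
compound 1 `COc1ccc(-c2[nH]c3cc(OC)cc(OC)c3c(=O)c2I)cc1`: > 86200 nM
compound 2 `COC(=O)c1cc(=O)c2cc(N)ccc2[nH]1`: > 33700 nM
compound 3 `COc1ccc(-c2cc(=O)c3c(OC)cc(OC)cc3n2S(=O)(=O)c2ccc([N+](=O)[O-])cc2)cc1`: > 29300 nM

Each of these three values is a limit of this assay rather than a number. Compound 3 sits at the limit of > 29300 nM in this assay, at which 1 of the 3 values shown sits. Compound 2 sits at the limit of > 33700 nM in this assay, at which 1 of the 3 values shown sits. Compound 1 sits at the limit of > 86200 nM in this assay, at which 1 of the 3 values shown sits. With every measured compound at a limit, compound 3 neither stands above nor below any other; all three are simply not active up to the concentrations tested. Among the compounds with values here, no two measured compounds differ in a single place, so no measured step is available to lean on.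

Compound 4 `COc1ccc(-c2cc(=O)c3c(OC)cc(OC)cc3n2S(=O)(=O)c2ccc(Br)cc2)cc1` has not been measured in this assay. It differs from compound 3 in one place: bromo in place of nitro on an aromatic carbon. The rest of the structure, with the same sulfonyl-linked aryl group on the shared core, is kept. Within the data shown here, with compound 3 at a limit and no measured step in hand, the step from compound 3 to compound 4 in this assay is expected to be a step that the limit leaves unreadable from compound 3 to compound 4, meaning none beyond the scatter. Compound 4 is therefore expected to give about 40000 nM, in a range from 8000 nM to 120000 nM, and most likely to return only a limit of the assay again.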

Compound 4, half-maximal effective concentration: 16300 nM
The estimate for compound 4 lay 2.5-fold (0.39 log units) above the measured number, within the range that was stated.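

Compound 4 is the only compound shown that gives a number rather than a limit in this assay, which makes this position on the sulfonyl-linked aryl group the first place in the series with a readable effect. The change from 4-nitrophenyl to 4-bromophenyl gives an at least 1.7-fold lower number from compound 3 to compound 4 (0.25 log units; that floor lies within the scatter), so this single replacement is enough to bring the compound within the tested range, although the printed floor alone does not establish a step beyond the scatter. The true size of the step cannot be read, as compound 3 carries only a limit: the limit of > 29300 nM in this assay, at which 1 of the 4 values shown sits.

The shown compounds leave open whether the number of compound 4 comes from the presence of bromo or the absence of nitro, as this one pair cannot separate the two, and no cause for the step can be assigned from it. From the compounds shown here alone, how a carboxylic acid, an amine or a methoxy group on the same aromatic carbon would read in this assay also remains open, as does any trend at this position beyond this single pair.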